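The source may report more compounds than this note shows. Statements on the series, on what has been measured and on what is new or still open speak of the compounds shown alone.

Compound 1 `CCCn1c(=O)[nH]c2nc(-c3ccc(S(=O)(=O)N4CCN(c5cccc(Br)c5)CC4)cc3)[nH]c2c1=O`: 0.234 nM
Compound 2 `CCCn1c(=O)[nH]c2nc(-c3ccc(S(=O)(=O)N4CCN(c5ccccc5F)CC4)cc3)[nH]c2c1=O`: 3.22 nM
Compound 3 `CCCn1c(=O)[nH]c2nc(-c3ccc(S(=O)(=O)N4CCN(c5ccc(C)cc5)CC4)cc3)[nH]c2c1=O`: 0.706 nM

These three compounds share one core and differ only in the aromatic group carried on the amine nitrogen of the ring at the far end of the sulfonamide. They were measured in an assay on CHO cells for displacement of a labelled ligand from adenosine receptor A2b (Homo sapiens), read by scintillation counting, with a stated time of 75 min, in the presence of a further agent that is not named here; on this read-out lower numbers stand for stronger inhibition and higher numbers for weaker inhibition. Compound 3 gives 0.706 nM, the second highest of the three numbers: the nearest is a 3.0-fold higher number from compound 1 to compound 3 (0.48 log units; beyond the scatter), the furthest a 4.6-fold lower number from compound 2 to compound 3 (0.66 log units; beyond the scatter), both beyond the scatter.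

Compound 4 `CCCn1c(=O)[nH]c2nc(-c3ccc(S(=O)(=O)N4CCN(c5ccccc5)CC4)cc3)[nH]c2c1=O` takes the step from compound 3 one notch further, with hydrogen in place of methyl on an aromatic carbon, that is, 4-methylphenyl becomes plain phenyl. Among the compounds with values here, no measured step removes this methyl, but the three steps that swap the aromatic group bear on it: the two modest ones just named, and the large one a 14-fold higher number from compound 1 to compound 2 (1.14 log units; beyond the scatter). Removing a single carbon from a group whose changes so far moved the number by modest amounts suggests a small shift, if any, expected toward a higher number. Compound 4 is therefore estimated at 1 nM, with a range from 0.4 nM to 2.5 nM, an expected step of a 1.4-fold higher number from compound 3 to compound 4 (0.15 log units; within the scatter).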

Compound 4, inhibition constant: 0.643 nM
Estimate against measurement, compound 4: 1.6-fold (0.19 log units) above; low and high end bracket the measured number.
By their numbers in this assay, from the lowest: compound 1; then compounds 4 and 3 (each within the scatter of the next); then compound 2.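

Plain phenyl, with hydrogen in place of the methyl, reads level with the 4-methylphenyl group in this assay (a 1.1-fold lower number from compound 3 to compound 4 (0.04 log units; within the scatter)), so this methyl can go without a readable change. Phenyl also gives the series an unsubstituted reference point: hydrogen in place of fluoro gives a stronger result (a 5.0-fold lower number from compound 2 to compound 4 (0.70 log units; beyond the scatter)), while hydrogen in place of bromo gives a weaker one (a 2.7-fold higher number from compound 1 to compound 4 (0.44 log units; beyond the scatter)), so substituents on this ring can move the number either way from phenyl. No measurement here accounts for these differences.

The 2-fluorophenyl and 3-bromophenyl groups differ from each other in both the halogen and its place on the ring, so the two influences remain unseparated. Going by these compounds, how a methoxy group or a nitrile on this ring would compare with plain phenyl also remains open.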